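Imidazole Replaced by Methylaminomethyl on the Saturated Carbon

The source may hold more compounds than are shown below. What is called first, only, known or untested is meant among the compounds shown, and "the series" means these compounds.

Measured compounds in an assay on isolated protein (Cricetulus griseus) for binding affinity to Alpha-1B adrenergic receptor (Mesocricetus auratus), read by radioligand binding; on this read-out lower numbers stand for stronger inhibition and higher numbers for weaker inhibition:
Compound 1 `CC(C)S(=O)(=O)Nc1cccc2c1CCCC2c1c[nH]cn1` — < 10000 nM, a limit.
Compound 2 `CS(=O)(=O)Nc1cccc2c1CCCCC2c1c[nH]cn1` — 10000 nM.
Compound 3 `CCS(=O)(=O)Nc1cccc2c1CCCC2c1c[nH]c(C)n1` — < 10000 nM, a limit.

For compound 3 this assay reports only a limit, < 10000 nM. Compound 1 sits at the same limit, as the limit of < 10000 nM in this assay, at which 2 of the 3 values shown sit, records. Compound 2 alone stands at a number, 10000 nM. For the measured compounds named here, no pair of measured compounds differs in a single place, so nothing measured shows how a change on the saturated ring carbon moves binding. Compound 4 `CCS(=O)(=O)Nc1cccc2c1CCCC2CNC` differs from compound 3 by (methylamino)methyl in place of 2-methyl-1H-imidazol-4-yl on a saturated ring carbon. Going by the values given here, with no measured step to rest on, the step from compound 3 to compound 4 is expected to be a step that the limit leaves unreadable from compound 3 to compound 4, no clear direction beyond the scatter. For compound 4 the estimate in this assay is 3000 nM, between 500 nM and 20000 nM.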

Compound 4, inhibition constant: < 10000 nM
Compound 4: only a limit was reported (the forecaster's own chance of this, stated with the estimate: 35%); the middle value lies beyond the limit too.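

For the compounds shown here, compound 3 and compound 4 both stand at a limit in this assay, so no step between them can be read: the limit of < 10000 nM in this assay, at which 3 of the 4 values shown sit.

The compounds shown leave open whether (methylamino)methyl in place of 2-methyl-1H-imidazol-4-yl on a saturated ring carbon changes binding at all.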